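The source may report more compounds than this note shows. Statements on the series, on what has been measured and on what is new or still open speak of the compounds shown alone.

Measured in a functional assay on DU-145 cells (Homo sapiens) for inhibition, read by trypan blue exclusion, with a stated time of 96 h; on this read-out lower numbers stand for stronger inhibition of growth and higher numbers for weaker inhibition of growth:
compound 1 `Cc1ccc(/C=C(/SCc2ccc(Cl)cc2Cl)C(=O)c2ccc(Cl)cc2)s1` gives 50000 nM
compound 2 `Cc1ccc(/C=C(/SCc2ccc(Cl)cc2)C(=O)c2ccc(Cl)cc2)s1` gives 50000 nM
compound 3 `COc1ccc(S/C(=C/c2ccc(C)s2)C(=O)c2ccc(Cl)cc2)cc1` gives 50000 nM

Compound 1 stands level with compounds 2 and 3 in this assay; the steps of no change at the digits printed from compound 1 to compound 2 (within the scatter), no change at the digits printed from compound 1 to compound 3 (within the scatter) and no change at the digits printed from compound 2 to compound 3 (within the scatter) all lie within the scatter. Those steps concern the group on the sulfur or a chloro on an aromatic carbon, and none of them touches the double-bonded chain carbon at which compound 4 `O=C(/C(=C\c1c(O)cc(O)cc1O)SCc1ccc(Cl)cc1Cl)c1ccc(Cl)cc1` differs from compound 1: 2,4,6-trihydroxyphenyl in place of 5-methylthiophen-2-yl on a double-bonded chain carbon bound to a double-bonded chain carbon. Going by the values given here, no measured step therefore bears on this change, and the three flat values give no direction for it. Compound 4 is expected at 40000 nM, within 8000 nM to 50000 nM, a step of a 1.3-fold lower number from compound 1 to compound 4 (0.10 log units; within the scatter) that is estimated, not measured.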

Compound 4, concentration for 50% growth inhibition: 25000 nM
Compound 4: the middle estimate sits 1.6-fold (0.20 log units) above what was measured; the measured number falls inside the stated range.
By their numbers in this assay, from the lowest: compounds 4, 1, 2 and 3 (each within the scatter of the next).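

In this assay, the double-bonded chain carbon bound to a double-bonded chain carbon now has a measured step: 2,4,6-trihydroxyphenyl in place of 5-methylthiophen-2-yl gives a 2.0-fold lower number from compound 1 to compound 4 (0.30 log units; within the scatter), so this exchange of a five-membered aromatic ring with 1 hetero atom for a six-membered carbon ring with 3 hydrogen-bond donors stays inside the scatter. No measurement is available that explains this result.

As far as these compounds go, whether an amine or a carboxylic acid at this place would give a step beyond the scatter remains open. Also open, from the compounds shown here alone, is whether 2,4,6-trihydroxyphenyl gives the same result with 4-chlorobenzyl or 4-methoxyphenyl on the sulfur.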